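Changing the Ring on a Sulfonamide Nitrogen

This account rests on a few compounds, and the source may have more. Where it says the series, first, only, none or still open, it means among the compounds named here.

Three measured compounds share one core and differ only in the ring on a sulfonamide nitrogen. In a functional assay on HT-29 cells (Homo sapiens) for antiproliferative activity, read by sulforhodamine B assay, with a stated time of 72 h (a higher number here means a weaker inhibitor, a lower number a stronger inhibitor), compound 1 `Cc1cc(C)nc(NS(=O)(=O)c2ccc(Nc3nncc4ccccc34)cc2)n1` gives 3.3 nM, compound 2 `O=S(=O)(Nc1ncccn1)c1ccc(Nc2nncc3ccccc23)cc1` gives 29 nM, and compound 3 `O=S(=O)(Nc1ccccn1)c1ccc(Nc2nncc3ccccc23)cc1` gives 38 nM. Compound 3 has the highest number of the three, but it stands level with compound 2, as a 1.3-fold higher number from compound 2 to compound 3 (0.12 log units; within the scatter) shows. Compound 1 is the strongest inhibitor here, with an 8.8-fold higher number from compound 1 to compound 2 (0.94 log units; beyond the scatter) and a 12-fold higher number from compound 1 to compound 3 (1.06 log units; beyond the scatter).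

Compound 4 `Cc1cc(NS(=O)(=O)c2ccc(Nc3nncc4ccccc34)cc2)no1` has not yet been measured. It has 5-methyl-1,2-oxazol-3-yl in place of pyridin-2-yl on a sulfonamide nitrogen.

Within the data shown here, no measured compound carries this five-membered ring, so the evidence is indirect. One ring exchange changed little, giving a 1.3-fold higher number from compound 2 to compound 3 (0.12 log units; within the scatter). Among the measured compounds shown here, the larger changes came from leaving compound 1, the only measured compound with a methyl-bearing ring, as a 12-fold higher number from compound 1 to compound 3 (1.06 log units; beyond the scatter) shows. Compound 4 also has a methyl group, but three compounds cannot establish a rule, so only a slight lean towards a lower number seems reasonable. The expected step in this assay is a 1.9-fold lower number from compound 3 to compound 4 (0.28 log units; within the scatter). For compound 4 the estimated value is 20 nM, with an expected range from 5 nM to 80 nM.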

Compound 4, half-maximal inhibitory concentration: 23 nM
For compound 4 the middle estimate is 1.2-fold (0.06 log units) below the measured one, within the range that was stated.
By their numbers in this assay, from the lowest: compound 1; then compounds 4, 2 and 3 (each within the scatter of the next).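

Compound 4 shows that the ring on the sulfonamide nitrogen need not be six-membered for the number in this assay to stay level with those of the unsubstituted rings: 5-methyl-1,2-oxazol-3-yl, a five-membered aromatic ring with 2 hetero atoms, gives a 1.7-fold lower number from compound 3 to compound 4 (0.22 log units; within the scatter) against pyridin-2-yl and a 1.3-fold lower number from compound 2 to compound 4 (0.10 log units; within the scatter) against pyrimidin-2-yl. Among these three compounds, then, the exchanges of ring size and hetero atoms seen here make no difference that can be told from the scatter. Among these compounds, compound 1 remains apart, with a 7.0-fold higher number from compound 1 to compound 4 (0.84 log units; beyond the scatter), so having a methyl-bearing ring does not by itself bring a compound to the level of compound 1, and 4,6-dimethylpyrimidin-2-yl is still the only group here that stands clear of the others.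

No measurement shown here accounts for the position of compound 1 or for the level numbers of the other three. The compounds shown also leave open how a pyrimidin-2-yl ring with a single methyl group, or a ring carrying an amine or a carboxylic acid, would read in this assay.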